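The source may report more compounds than this note shows. Statements on the series, on what has been measured and on what is new or still open speak of the compounds shown alone.

Measured compounds:

Compound 1, `O=C(Nc1ccc(-c2cscn2)cc1)C1CCCN(Cc2cccc(F)c2F)C1`, in a functional assay on A-375 cells (Homo sapiens) for antiproliferative activity (a higher number here means a weaker inhibitor, a lower number a stronger inhibitor), compound 1 gives 1480 nM.
Compound 2, `O=C(Nc1ccc(-c2nccs2)cc1)C1CCCN(Cc2ccc(F)c(F)c2)C1`, in this assay compound 2 gives 240 nM.

Of the two numbers, compound 2 holds the lower one, and the number of compound 1 lies above it by a gap that is beyond the usual scatter. Compounds 1 and 2 differ from each other in more than one place, so nothing beyond the two values themselves can be said of what separates them.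

Compound 3, `O=C(Nc1ccc(-c2cc[nH]c2)cc1)C1CCCN(Cc2ccc(F)c(F)c2)C1`, has not yet been measured. It differs from compound 2 in a single place: 1H-pyrrol-3-yl in place of 1,3-thiazol-2-yl on an aromatic carbon. Among the compounds with values here, no pair of measured compounds shows this same change, so there is no measured step to lean on. The group that enters carries a donor where the group that leaves carried acceptors, and the account treats this as a change likely to move the number somewhat upward, though not far. The step from compound 2 to compound 3 is expected to be a 2.3-fold higher number from compound 2 to compound 3 (0.36 log units; beyond the scatter) in this assay. For compound 3 the estimated value in this assay is 550 nM, with a likely range from 170 nM to 1800 nM.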

Compound 3, half-maximal inhibitory concentration: 1420 nM
Beside the measured number, compound 3's estimate is 2.6-fold (0.41 log units) below it; low and high end bracket the measured number.
By their numbers in this assay, from the lowest: compound 2; then compounds 3 and 1 (each within the scatter of the next).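

Within the data shown here, compound 2 and compound 3 form the first pair that differ in one place, so this assay can now be read for a single change: 1H-pyrrol-3-yl in place of 1,3-thiazol-2-yl, on an aromatic carbon para to a large group, gives a 5.9-fold higher number from compound 2 to compound 3 (0.77 log units; beyond the scatter). The position therefore does not treat these two five-membered aromatic rings alike, even though each group has the same count of heavy atoms and the rest of the molecule stays the same; the change removes the sulfur and replaces hydrogen-bond acceptors with a hydrogen-bond donor. Nothing measured here connects the step to any one of these differences, and no property of either group has been measured in a way that accounts for it.

The compounds shown leave open which of these differences matters, since sulfur, ring nitrogen count and the ring hydrogen all change together in this one step. A thiophen-3-yl group, which keeps sulfur with no ring nitrogen, or a 1-methyl-1H-pyrrol-3-yl group, which keeps the pyrrole ring with a methyl on its nitrogen, would separate them at this position.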